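Removing the fluoro group from compound 2

A few compounds are considered here, and "the series" means these few. Any claim that something is new, unique, unknown or untested is made for them only; others in the source may bear on it.

Compound 2 `CC(N)C[Se]c1ccc(F)cc1` gives 10500 nM in an assay on isolated protein for inhibition of Amine oxidase [flavin-containing] A (Homo sapiens), read by fluorescence and spectrophotometry (a higher number here means a weaker inhibitor, a lower number a stronger inhibitor), the highest of the three numbers in hand. Compound 3 `CC(N)CSc1cccc(Br)c1` gives 7820 nM in this assay, a number within the scatter of compound 2. Compound 1 `CC(N)CSc1ccccc1Br` gives 724 nM in this assay, a clearly lower number than compound 2. Compound 4 `CC(N)C[Se]c1ccccc1` differs from compound 2 at one point only: hydrogen in place of fluoro on an aromatic carbon. Among the compounds with values here, no pair of measured compounds shares that change, so neither its direction nor its size is anchored by data. The expected step from compound 2 to compound 4 is a modest move toward a lower number, possibly no larger than the scatter, a 1.8-fold lower number from compound 2 to compound 4 (0.24 log units; within the scatter). Compound 4 is estimated at 6000 nM in this assay, within a range from 1500 nM to 20000 nM.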

Compound 4, half-maximal inhibitory concentration: 9790 nM
For compound 4 the middle estimate is 1.6-fold (0.21 log units) below the measured one; measured number inside the range.
By their numbers in this assay, from the lowest: compound 1; then compounds 3, 4 and 2 (each within the scatter of the next).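

In this assay the change from fluoro to hydrogen on this aromatic carbon now has a measured size: a 1.1-fold lower number from compound 2 to compound 4 (0.03 log units; within the scatter) and so no shift that can be told from the scatter. This holds for this one pair only, on the selenium-bearing core of compound 2. No measurement on hand offers an explanation for this result.

On these data alone, whether a methoxy or a trifluoromethyl group on the same carbon would move the number stays open. Also open, as far as these compounds go, is whether the same change would be as small on a sulfur-bearing core such as that of compound 3.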